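A few compounds are considered here, and "the series" means these few. Any claim that something is new, unique, unknown or untested is made for them only; others in the source may bear on it.

Measured in a functional assay on MDA-MB-231 cells (Homo sapiens) for cytotoxicity, read by MTT assay, with a stated time of 48 h; on this read-out lower numbers stand for stronger inhibition and higher numbers for weaker inhibition:
Compound 1 `C=C(C(=O)c1cc(OC)c(O)c(OC)c1)[C@H](CO)C(=O)c1cc(OC)c(O)c(OC)c1`: 53.3 ug/mL
Compound 2 `C=C(C(=O)c1cc(OC)c(O)c(OC)c1)C(CO)C(=O)c1cc(OC)c(O)c(OC)c1`: 51.4 ug/mL

For the measured compounds named here, compound 2, at 51.4 ug/mL, stands within the scatter of the only other measured compound, so neither can be ranked above the other. Compound 3 `C=C(C(=O)c1cc(OC)c(O)c(OC)c1)[C@@H](CO)C(=O)c1cc(OC)c(O)c(OC)c1` differs from compound 2 as follows: the two compounds have the same atoms and bonds; at least one stereo element is drawn with a configuration in one of them and without one in the other: 1 of 1 stereo elements differ; a stereocentre at a saturated chain carbon is drawn without a configuration in compound 2 and S in compound 3. Going by the values given here, one measured step bears on this change, since it concerns the same kind of difference: the fact that one of compounds 1 and 2 is drawn with a defined configuration and the other without, at the place where they differ. That step is a 1.0-fold lower number from compound 1 to compound 2 (0.02 log units; within the scatter). Among the compounds with values here, it shows what a drawn R configuration does, while the S configuration has no measurement yet. On the strength of compound 1 and its step of a 1.0-fold lower number from compound 1 to compound 2 (0.02 log units; within the scatter), no step beyond the scatter is expected in this assay, in either direction. The expected step is a 1.0-fold higher number from compound 2 to compound 3 (0.01 log units; within the scatter). For compound 3 the estimated value is 52 ug/mL, with an expected range from 30 ug/mL to 90 ug/mL.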

Compound 3, half-maximal inhibitory concentration: 28.7 ug/mL
Beside the measured number, compound 3's estimate is 1.8-fold (0.26 log units) above it; measured number below the stated range.
By their numbers in this assay, from the lowest: compounds 3, 2 and 1 (each within the scatter of the next).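

In this assay, the S form gives this stereocentre its first reading, and a 1.9-fold lower number from compound 1 to compound 3 (0.27 log units; within the scatter) sets the two drawn configurations directly against each other, where the earlier pair had set only the R form against an undefined drawing. That step and a 1.8-fold lower number from compound 2 to compound 3 (0.25 log units; within the scatter) are both within the scatter, so the configuration at this saturated chain carbon does not separate the three compounds in this assay. Any gap in this comparison can be read against the drawn configuration alone: the fact that compounds 1 and 3 differ only in the configuration as drawn

The compounds shown leave open which forms are present in compound 2, drawn without a configuration at this carbon. They also leave open whether the configuration would count for more with another group on this carbon, such as a carboxylic acid or an amine.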